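The compounds below may be only part of what the source reports. "The series", "measured", "known", "first", "only" and "open" are said of these compounds alone.

Measured so far:
Compound 1 `COc1cc2c(Oc3ccc(NC(=O)c4nn(-c5ccccc5)c(=O)c5ccccc45)cc3F)ccnc2cc1OCCCN1CCCC1`: 1130 nM
Compound 2 `COc1cc2c(Oc3ccc(NC(=O)c4nn(-c5ccccc5)c(=O)c5ccccc45)cc3F)ccnc2cc1OCCCN1CCCCC1`: 1880 nM

Both numbers come from a functional assay on MDA-MB-231 cells (Homo sapiens) for cytotoxicity, read by MTT assay, with a stated time of 72 h; a higher number here means a weaker inhibitor, a lower number a stronger inhibitor. For the measured compounds named here, compound 2 holds the higher of the two numbers, but its only neighbour is compound 1, and the step of a 1.7-fold higher number from compound 1 to compound 2 (0.22 log units; within the scatter) stays within the scatter, so the two compounds stand level on the evidence so far.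

Compound 3 `COc1cc2c(Oc3ccc(NC(=O)c4nn(-c5ccccc5)c(=O)c5ccccc45)cc3F)ccnc2cc1OCCCN1CCC(C)CC1` is the next point. It differs from compound 2 by methyl in place of hydrogen on a saturated ring carbon — methyl in place of hydrogen on a saturated ring carbon, three ring bonds from the ring nitrogen. Going by the values given here, the one measured step that touches this end of the chain is a 1.7-fold higher number from compound 1 to compound 2 (0.22 log units; within the scatter), in which the whole terminal ring was exchanged without moving the number beyond the scatter. Among the compounds with values here, no measured compound carries a substituent on that ring, so the methyl is untested ground. Given that the ring exchange itself did nothing beyond the scatter, no step beyond the scatter is expected for the methyl either. The expected step of a 1.0-fold higher number from compound 2 to compound 3 (0.00 log units; within the scatter) is taken as within the scatter. Compound 3 is therefore estimated at 1900 nM, with a range from 900 nM to 4000 nM.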

Compound 3, half-maximal inhibitory concentration: 1480 nM
The estimate for compound 3 lay 1.3-fold (0.11 log units) above the measured number; the measured number falls inside the stated range.
By their numbers in this assay, from the lowest: compounds 1, 3 and 2 (each within the scatter of the next).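

In this assay, methyl in place of hydrogen on the saturated ring carbon three ring bonds from the ring nitrogen gives a 1.3-fold lower number from compound 2 to compound 3 (0.10 log units; within the scatter) and so adds a first substituent on the terminal ring without a step beyond the scatter. Exchanging the terminal ring for 4-methylpiperidin-1-yl in place of pyrrolidin-1-yl gives a 1.3-fold higher number from compound 1 to compound 3 (0.12 log units; within the scatter) as well, which leaves all three terminal groups level on these numbers. Nothing at hand bears on why these steps stay so small.

Still open, from the compounds shown here alone, is whether a hydroxyl, a carboxylic acid or a phenyl on that same ring carbon would move the number beyond the scatter. Also open, going by these compounds, is how a morpholin-4-yl ring at the chain end, or a longer chain carrying the same piperidin-1-yl ring, would read on this core.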